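A few compounds are considered here, and "the series" means these few. Any claim that something is new, unique, unknown or untested is made for them only; others in the source may bear on it.

Measured compounds in an assay for inhibition of Indoleamine 2,3-dioxygenase 1 (Homo sapiens), read by fluorescence, with a stated time of 1 h; a higher number here means a weaker inhibitor, a lower number a stronger inhibitor:

compound 1 `COc1nonc1/C(=N/O)Nc1ccc(F)c(Br)c1` gives 230 nM
compound 2 `NS(=O)(=O)CC(=O)NCCSc1nonc1/C(=N/O)Nc1ccc(F)c(Br)c1` gives 71 nM
compound 3 `CS(=N)(=O)CC(=O)NCCSc1nonc1/C(=N/O)Nc1ccc(F)c(Br)c1` gives 61 nM

Compound 3 holds the lowest number of the three in this assay. Compound 2 lies within the scatter of it, so no order between compounds 2 and 3 is claimed; compound 1 lies beyond the scatter on the higher side.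

Compound 4 `CSc1nonc1/C(=N/O)Nc1ccc(F)c(Br)c1` is not yet measured. Relative to compound 3 the change is a hydrogen atom in place of a group of 9 heavy atoms (4 carbon, 2 nitrogen, 2 oxygen, 1 sulfur; no ring), on a saturated chain carbon bound to a sulfur, so the chain is cut back to the carbon bound to the sulfur.

Within the data shown here, the one measured step, a 1.2-fold lower number from compound 2 to compound 3 (0.07 log units; within the scatter), exchanges only the terminal group of that chain and does not test its removal. The nearest point of comparison is compound 1, which carries no extended chain at all and gives 230 nM against 61 nM for compound 3, a gap beyond the scatter. Whether the full chain or only part of it accounts for that gap cannot be read from these three numbers.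

Compound 4 is therefore expected to fall between compound 3 and compound 1, with a step of a 3.0-fold higher number from compound 3 to compound 4 (0.47 log units; beyond the scatter) toward a higher number, because compound 1 gives 230 nM with no chain present. The estimate for compound 4 is 180 nM, range 70 nM to 500 nM.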

Compound 4, half-maximal inhibitory concentration: 560 nM
The estimate for compound 4 lay 3.1-fold (0.49 log units) below the measured number; measured number above the stated range.
By their numbers in this assay, from the lowest: compounds 3 and 2 (each within the scatter of the next); then compound 1; then compound 4.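

In this assay, the chain on the saturated chain carbon bound to a sulfur matters far more than its terminal group: its removal gives a 9.2-fold higher number from compound 3 to compound 4 (0.96 log units; beyond the scatter) and a 7.9-fold higher number from compound 2 to compound 4 (0.90 log units; beyond the scatter), whereas the terminal exchange alone gave a 1.2-fold lower number from compound 2 to compound 3 (0.07 log units; within the scatter), within the scatter. Methylsulfanyl in place of methoxy on an aromatic carbon gives a 2.4-fold higher number from compound 1 to compound 4 (0.39 log units; beyond the scatter), so compound 1 is not an equivalent chain-free reference, and the effect of the chain is properly read against compound 4, which differs from compounds 2 and 3 in that one place. No supporting data explain the size or direction of any of these steps.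

Which part of the chain carries the effect remains open, since compounds 2 and 3 keep the whole chain while compound 4 loses all of it; a shorter chain ending in an amine would divide it. Also open, on these data alone, is whether the terminal group tolerates a carboxylic acid, whether a longer chain goes further, and whether the same chain on an oxygen in place of the sulfur gives the same result.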